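The source may report more compounds than this note shows. Statements on the series, on what has been measured and on what is new or still open speak of the compounds shown alone.

Compound 1 `OC[C@H]1OC(n2cnc3c(Nc4ccccc4)nccc32)[C@H](O)[C@@H]1O`: 4%
Compound 2 `CSc1nccc2c1ncn2C1O[C@H](CO)[C@@H](O)[C@H]1O`: 24%
Compound 3 `OC[C@H]1OC(n2cnc3c(S)nccc32)[C@H](O)[C@@H]1O`: 6%

All three share one core and differ only in the group on one aromatic carbon, each tested in a functional assay (Homo sapiens) for inhibition of Nucleic Acid, tested at 100 uM; a higher number here means more inhibition at the concentration tested (going by the name of the read-out), a lower number less inhibition. Compound 3 stands second highest of the three: its number sits within the scatter of compound 1, and only a number 18 percentage points lower from compound 2 to compound 3 (beyond the scatter) is beyond the scatter.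

Compound 4 `CCCCCCNc1nccc2c1ncn2C1O[C@H](CO)[C@@H](O)[C@H]1O` is reached from compound 3 by hexylamino in place of sulfanyl on an aromatic carbon. Going by the values given here, two measured steps bear on this change. a number 2 percentage points higher from compound 1 to compound 3 (within the scatter) shows that swapping sulfanyl for an amino group, the anilino of compound 1, left the number essentially unchanged, while a number 18 percentage points lower from compound 2 to compound 3 (beyond the scatter) shows that a methyl on the sulfur, not a change at the nitrogen, gave the only modest shift. Hexylamino is again an amino group, so for compound 4 no step beyond the scatter is expected, a number 3 percentage points higher from compound 3 to compound 4 (within the scatter). Compound 4 is therefore estimated at 9%, within 0% to 28%.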

Compound 4, a percentage reported as inhibition, at one concentration (the size of the read-out at that concentration, not a potency): 8%
Compound 4: middle estimate off by 1 percentage points, on the high side; the range from low to high includes it.
By their numbers in this assay, from the lowest: compounds 1, 3 and 4 (each within the scatter of the next); then compound 2.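

In this assay, a hexyl chain on the nitrogen reads the same as a phenyl ring there: a number 4 percentage points higher from compound 1 to compound 4 (within the scatter). Hexylamino in place of sulfanyl also makes no readable difference, a number 2 percentage points higher from compound 3 to compound 4 (within the scatter), whereas a number 16 percentage points lower from compound 2 to compound 4 (beyond the scatter), so among these compounds only methylsulfanyl stands apart from the other groups at this aromatic carbon. Nothing available explains why methylsulfanyl differs from the rest.

On these data alone, it remains open whether ethylsulfanyl, with a longer chain on the sulfur, would keep the higher number of compound 2. A plain amino group, with no carbon chain on the nitrogen, is also untested among the compounds shown.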